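The source may report more compounds than this note shows. Statements on the series, on what has been measured and on what is new or still open speak of the compounds shown alone.

The compounds here share one core, a chromenone carrying a dithiocarbamate side chain, and differ in the ring on the thiocarbonyl carbon and in a substituent on the aromatic ring. Compound 1 `O=c1cc(CSC(=S)N2CCCCC2)oc2cc(Cl)ccc12` gives 3000 nM in a functional assay on MDA-MB-435S cells (Homo sapiens) for antiproliferative activity, read by MTT assay, with a stated time of 72 h; a higher number here means a weaker inhibitor, a lower number a stronger inhibitor. Compound 2 `O=c1cc(CSC(=S)N2CCCC2)oc2cc(Cl)ccc12` reaches only the limit of the assay in this assay, > 25000 nM, so no number is known for it. Among the measured compounds shown here, compound 3 `O=c1cc(CSC(=S)N2CCOCC2)oc2ccccc12` gives 22200 nM in this assay, the highest of the two numbers so far, with compound 1 the nearest below it.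

For the measured compounds named here, the one measured step between neighbours, an at least 8.3-fold higher number from compound 1 to compound 2 (0.92 log units; beyond the scatter), concerns the ring on the thiocarbonyl carbon, and its size is only known as a bound because of the limit of > 25000 nM in this assay, at which 1 of the 3 values shown sits. Compound 4 `O=c1cc(CSC(=S)N2CCOCC2)oc2cc(Cl)ccc12` differs from compound 3 at a different place: chloro in place of hydrogen on an aromatic carbon. Going by the values given here, no measured pair shows what this exchange does on its own, since compound 1 and compound 2 both already carry the chloro group. The expectation for this assay therefore has to stay wide, with no step beyond the scatter assumed in either direction. Compound 4 is estimated at 15000 nM, within a range from 5000 nM to 40000 nM, which means an expected step of a 1.5-fold lower number from compound 3 to compound 4 (0.17 log units; within the scatter).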

Compound 4, half-maximal inhibitory concentration: > 25000 nM
Compound 4 ended at the assay's limit; the forecaster's own chance of this, stated with the estimate: 25%; middle value at least 1.6-fold (0.22 log units) from the limit.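

The chloro group in place of hydrogen on the aromatic carbon can now be seen on its own, and in this assay it gives an at least 1.1-fold higher number from compound 3 to compound 4 (0.05 log units; that floor lies within the scatter), so this exchange shows no change beyond the scatter, though the true size of the step stays hidden behind a floor. Keeping the chloro group and changing only the ring on the thiocarbonyl carbon gives an at least 8.3-fold higher number from compound 1 to compound 4 (0.92 log units; beyond the scatter), so morpholin-4-yl joins pyrrolidin-1-yl in falling well short of piperidin-1-yl, which makes the piperidin-1-yl ring the one chloro-bearing case with a measured number, with compound 1 at 3000 nM. The step from compound 2 to compound 4 cannot be read, because neither compound has a number to compare: the limit of > 25000 nM in this assay, at which 2 of the 4 values shown sit.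

From the compounds shown here alone, whether the chloro group changes anything when the ring is piperidin-1-yl stays open, since that ring appears here only together with chloro. Also open, going by these compounds, is how far the preference for piperidin-1-yl extends, for example to a larger azepan-1-yl ring or an open-chain diethylamino group on the thiocarbonyl carbon.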